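The source may hold more compounds than are shown below. What is called first, only, known or untested is meant among the compounds shown, and "the series" means these compounds.

For the measured compounds named here, compound 1 `COc1cc(Cl)nc(NC(=S)NC(=O)c2c(-c3ccc(Cl)cc3Cl)noc2C)n1` is one of two compounds measured in a functional assay on the whole organism for inhibition, with Digitaria ciliaris as the target, with a stated time of 72 h, tested at 10 mg/L; on this read-out lower numbers stand for less inhibition of growth and higher numbers for more inhibition of growth at the one concentration tested. In this assay compound 1 gives 14.6%, the lower of the two numbers, while compound 2 `Cc1onc(-c2ccc(Cl)cc2Cl)c1C(=O)/N=c1/nc2nc(Cl)cc(C)n2s1` gives 32.8%, a gap that lies beyond the usual scatter. Compound 3 `COc1cc(OC)nc(NC(=S)NC(=O)c2c(-c3ccc(Cl)cc3Cl)noc2C)n1` has not yet been measured. It differs from compound 1 in one place: methoxy in place of chloro on an aromatic carbon. Going by the values given here, no pair of measured compounds shows this same change, so the size of its effect is unknown from these data. The step of a number 0.4 percentage points higher from compound 1 to compound 3 (within the scatter) is expected to stay within the scatter. Compound 3 is estimated at 15%, with a range from 4% to 32%.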

Compound 3, percent growth inhibition at one concentration: 32%
The estimate for compound 3 lay 17 percentage points below the measured number, and the stated range covers the measured number.
By their numbers in this assay, from the lowest: compound 1; then compounds 3 and 2 (each within the scatter of the next).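

In this assay, replacing the 4-chloro-6-methoxypyrimidin-2-yl group with 4,6-dimethoxypyrimidin-2-yl gives a number 17.4 percentage points higher from compound 1 to compound 3 (beyond the scatter) at the shared core. For the compounds shown here, this shows that the read-out responds to what sits on this aromatic carbon next to the ring nitrogen, which no earlier pair could show. Nothing available bears on why the number rises.

This single pair cannot separate the loss of chloro from the gain of methoxy. Going by these compounds, how an amine or a longer chain such as ethoxy would read at this carbon remains open.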